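Swapping the Nitrophenol for Bromophenyl in Compound 1

The source may hold more compounds than are shown below. What is called first, only, known or untested is meant among the compounds shown, and "the series" means these compounds.

In a functional assay on DU-145 cells (Homo sapiens) for inhibition, read by trypan blue exclusion, with a stated time of 96 h (on this read-out higher numbers stand for weaker inhibition of growth and lower numbers for stronger inhibition of growth), compound 1 `O=C(O)c1ccc(C(=O)/C(=C\c2ccc(O)c([N+](=O)[O-])c2)SCc2ccc(Br)cc2)cc1` gives 50000 nM, the highest of the two numbers recorded. Among the compounds with values here, its nearest neighbour is compound 2 `COc1ccc(C(=O)/C(=C\c2ccc(O)c([N+](=O)[O-])c2)SCc2ccc(Br)cc2)cc1` with 10000 nM, and the change a 5.0-fold lower number from compound 1 to compound 2 (0.70 log units; beyond the scatter) is the only step that clears the scatter. Compound 3 `O=C(O)c1ccc(C(=O)/C(=C\c2ccc(O)c([N+](=O)[O-])c2)SCc2ccc(F)cc2)cc1` is reported only as a limit of this assay, > 100000 nM. The step of an at least 2.0-fold higher number from compound 1 to compound 3 (0.30 log units; that floor lies within the scatter) rests on that limit (the limit of > 100000 nM in this assay, at which 1 of the 3 values shown sits). Compound 4 `O=C(O)c1ccc(C(=O)/C(=C\c2ccc(Br)cc2)SCc2ccc(Br)cc2)cc1` differs from compound 1 in one place: 4-bromophenyl in place of 4-hydroxy-3-nitrophenyl on a double-bonded chain carbon bound to a double-bonded chain carbon. Neither measured step touches this part of the shared core, so no size of step is expected beyond the scatter in either direction. Compound 4 is therefore estimated at 50000 nM, within 15000 nM to 150000 nM, an expected step of no change at the digits printed from compound 1 to compound 4 (within the scatter).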

Compound 4, concentration for 50% growth inhibition: 1000 nM
For compound 4 the middle estimate is 50-fold (1.70 log units) above the measured one; the measured number lies below the stated range.
By their numbers in this assay, from the lowest: compound 4; then compound 2; then compound 1. At a limit, above all of these: compound 3.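

In this assay, the change at this position, on a double-bonded chain carbon bound to a double-bonded chain carbon, gives a 50-fold lower number from compound 1 to compound 4 (1.70 log units; beyond the scatter). The earlier steps shown here concerned other parts of the compound, so this one shows that the read-out also responds to the group held here, with the carboxy and bromo groups of compound 1 kept in compound 4. The data shown give no reason for this step.

On these data alone, it remains open whether the hydroxy or the nitro group accounts for the step, and how a chloro or an amine at the same place on the aromatic ring would read.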